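Aryl ketone variation and tolerated concentration in the series

A few compounds are considered here, and "the series" means these few. Any claim that something is new, unique, unknown or untested is made for them only; others in the source may bear on it.

Compound 1 `COC(=O)c1cc(-c2cccc(NC(=O)c3ccc(/C=C/C(=O)c4cc(F)ccc4F)cc3)c2)on1` in an ADME assay on Vero cells (Chlorocebus sabaeus) for cytotoxicity, read by MTT assay, with a stated time of 72 h (a lower number here means that less compound is tolerated, a higher number that more compound is tolerated), reaches only a limit, > 40 ug/mL. Compound 2 `COC(=O)c1cc(-c2cccc(NC(=O)c3ccc(/C=C/C(=O)c4ccc(OC)cc4OC)cc3)c2)on1` in this assay also sits at a limit, > 50 ug/mL. Compound 3 `COC(=O)c1cc(-c2cccc(NC(=O)c3ccc(/C=C/C(=O)c4ccc(OC)c(OC)c4)cc3)c2)on1` in this assay likewise ends at a limit, > 50 ug/mL. The steps a step that the two limits leave unreadable from compound 1 to compound 2, a step that the two limits leave unreadable from compound 1 to compound 3 and a step that the two limits leave unreadable from compound 2 to compound 3 therefore carry no readable size. Compound 4 `COC(=O)c1cc(-c2cccc(NC(=O)c3ccc(/C=C/C(=O)c4ccccc4Cl)cc3)c2)on1` differs from compound 1 by 2-chlorophenyl in place of 2,5-difluorophenyl on a carbonyl carbon. The three measured steps concern the same position on a carbonyl carbon, yet none gives a size, so no direction can be read for this assay. Given the limit of > 40 ug/mL in this assay, at which 1 of the 3 values shown sits, and (the limit of > 50 ug/mL in this assay, at which 2 of the 3 values shown sit), compound 4 is expected to sit near those limits as well, a step that the limit leaves unreadable from compound 1 to compound 4 not expected to pass the scatter. For compound 4 the estimate is 45 ug/mL, between 20 ug/mL and 100 ug/mL.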

Compound 4, half-maximal cytotoxic concentration: > 25 ug/mL
Compound 4: only a limit was reported; the forecaster's own chance of this, stated with the estimate: 70%; the middle value is on the limit's open side.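

Among these compounds, compound 4 also ends at a limit, > 25 ug/mL, so no step from compound 1, compound 2 or compound 3 to compound 4 can be read. The compounds shown leave open where any of them would reach a half-maximal cytotoxic concentration in this assay.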